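A Methyl on the Ring Oxygen, Tried on Two Cores

The source may report more compounds than this note shows. Statements on the series, on what has been measured and on what is new or still open speak of the compounds shown alone.

Compound 1 `O=C(CCCc1nc2ccccc2c(=O)[nH]1)N/N=C/c1cc(O)c(O)c(O)c1` and compound 2 `COc1cc(/C=N/NC(=O)CCCc2nc3ccccc3c(=O)[nH]2)cc(O)c1O` share one core, while compound 3 `O=C(CCc1nc2ccccc2c(=O)[nH]1)N/N=C/c1cc(O)c(O)c(O)c1` and compound 4 `COc1cc(/C=N/NC(=O)CCc2nc3ccccc3c(=O)[nH]2)cc(O)c1O` share another; how the two cores differ is not broken down here. In a physicochemical assay, read by spectrophotometry, with a stated time of 30 min (on this read-out lower numbers stand for stronger inhibition and higher numbers for weaker inhibition), compound 1 gives 78000000 nM and compound 2 gives 88000000 nM. The change between them, (methyl in place of hydrogen on an oxygen on an aromatic ring), made a step of a 1.1-fold higher number from compound 1 to compound 2 (0.05 log units; within the scatter). In this assay compound 3 gives 81000000 nM. Compound 4 carries the same change, (methyl in place of hydrogen on an oxygen on an aromatic ring), at a place described in the same words as before. Because the earlier step of a 1.1-fold higher number from compound 1 to compound 2 (0.05 log units; within the scatter) stayed within the scatter, a step of similar size is expected here, a 1.1-fold higher number from compound 3 to compound 4 (0.04 log units; within the scatter). Compound 4 is therefore expected to give about 88000000 nM, with a plausible range from 45000000 nM to 175000000 nM.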

Compound 4, half-maximal inhibitory concentration: 104000000 nM
Compound 4: the middle estimate sits 1.2-fold (0.07 log units) below what was measured, and the stated range covers the measured number.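

In this assay the change from hydroxy to methoxy gave a 1.3-fold higher number from compound 3 to compound 4 (0.11 log units; within the scatter) on one core and a 1.1-fold higher number from compound 1 to compound 2 (0.05 log units; within the scatter) on the other, so both steps lie within the scatter. For these two pairs, the methyl on the ring oxygen carries across the cores without a readable effect, but this does not show that it acts identically on both, as steps this small cannot be told apart from the spread of repeated measurements. Nothing measured here offers an explanation for these results.

The compounds shown leave open whether an ethyl group on that oxygen, or an amine or a carboxylic acid in place of the hydroxy, would give a step beyond the scatter. They also leave open whether the same methyl change would read alike on any core other than these two.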